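This account rests on a few compounds, and the source may have more. Where it says the series, first, only, none or still open, it means among the compounds named here.

In an ADME assay on HepG2 2.2.15 cells (Homo sapiens) for cytotoxicity, read by CCK-8 assay, with a stated time of 8 days (a lower number here means that less compound is tolerated, a higher number that more compound is tolerated), compound 1 `COc1ccc(-c2cc(NC(=O)c3ccc(OC)cc3O)c[nH]c2=O)cc1` gives 49900 nM, compound 2 `Cc1cccc(-c2cc(NC(=O)c3ccccc3O)c[nH]c2=O)c1` gives 98800 nM and compound 3 `COc1ccc(O)c(C(=O)Nc2c[nH]c(=O)c(-c3cccc(C)c3)c2)c1` gives 30100 nM. Compound 3 and compound 1 lie within the scatter of each other. Compound 2 stands apart, with a 3.3-fold lower number from compound 2 to compound 3 (0.52 log units; beyond the scatter), a modest step that comes with methoxy in place of hydrogen on an aromatic carbon.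

Compound 4 `CCOc1ccc(-c2cc(NC(=O)c3cc(OC)ccc3O)c[nH]c2=O)cc1` keeps the rest of compound 3 and changes one group: 4-ethoxyphenyl in place of 3-methylphenyl on an aromatic carbon. It carries 4-ethoxyphenyl in place of 3-methylphenyl on an aromatic carbon of a six-membered aromatic ring with 1 nitrogen. Among the compounds with values here, no measured step covers this exchange. Within the data shown here, the only step at hand, a 3.3-fold lower number from compound 2 to compound 3 (0.52 log units; beyond the scatter), is a different change, so it bears on the exchange only by showing how far one substitution has moved the number in this assay so far. It gives no direction for the new group, and the data hold no direct comparison for it. A shift beyond the scatter is therefore not expected, and the expected move is a 1.2-fold higher number from compound 3 to compound 4 (0.07 log units; within the scatter). For compound 4 the estimated value is 35000 nM, with an expected range of 13000 nM to 90000 nM.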

Compound 4, half-maximal cytotoxic concentration: 57700 nM
Compound 4: middle estimate off by 1.6-fold (0.22 log units), on the low side, within the range that was stated.
By their numbers in this assay, from the lowest: compounds 3, 1, 4 and 2 (each within the scatter of the next, the first and the last beyond it).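

In this assay, putting 4-ethoxyphenyl in place of 3-methylphenyl on an aromatic carbon, two atoms from the ring nitrogen, gives a 1.9-fold higher number from compound 3 to compound 4 (0.28 log units; within the scatter) and so leaves the two compounds within the scatter of each other. Within the data shown here, this is the first direct reading at this position, and it shows that the aryl group there can be exchanged for a larger one carrying a hydrogen-bond acceptor without a shift that stands clear of the scatter, whereas the only earlier step, the methoxy exchange on an aromatic carbon elsewhere in the molecule, gave a 3.3-fold lower number from compound 2 to compound 3 (0.52 log units; beyond the scatter) and lay beyond it. The compounds shown offer no measurement that could account for either result.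

Going by these compounds, with a single step at this position, it remains open whether an amine or a carboxylic acid on this aryl ring, or a longer chain than ethoxy, would carry the number beyond the scatter. It is also open whether the methoxy step would repeat in size with 4-ethoxyphenyl in place, as no partner lacking that methoxy group is shown for compound 4.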